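This account rests on a few compounds, and the source may have more. Where it says the series, first, only, none or still open, it means among the compounds named here.

Working notes on the series, continued.

In a functional assay on NCI-H460 cells (Homo sapiens) for inhibition, read by sulforhodamine B assay, with a stated time of 48 h (on this read-out higher numbers stand for weaker inhibition of growth and lower numbers for stronger inhibition of growth), compound 1 (`CC1=CC[C@H](C(C)(C)NC(=S)NN)CC1`) gives only a limit, > 100000 nM, and not a number. Compound 2 (`CC1=CC[C@H](C(C)(C)NC(=S)N/N=C/c2ccccc2O)CC1`) gives 8400 nM in this assay, which is the only number shown in this read-out so far. Among the measured compounds shown here, the one other value shown belongs to compound 1 and is recorded as the limit of > 100000 nM in this assay, at which 1 of the 2 values shown sits. For the measured compounds named here, no step between measured compounds is available.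

Compound 3 (`CC1=CC[C@H](C(C)(C)NC(=S)N/N=C/c2ccc(Cl)cc2)CC1`) differs from compound 2 by one change: 4-chlorophenyl in place of 2-hydroxyphenyl on a carbon with a double bond to nitrogen. Going by the values given here, with only the single number of compound 2 to build on, no measured step shows how this exchange moves the read-out.

The expectation for compound 3 is a step of a 1.8-fold higher number from compound 2 to compound 3 (0.25 log units; within the scatter) towards weaker growth inhibition in this assay, modest and possibly within the scatter. Compound 3 is estimated at 15000 nM, with a range from 4000 nM to 60000 nM, pending the measurement.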

Compound 3, concentration for total growth inhibition: 21100 nM
Compound 3: the middle estimate sits 1.4-fold (0.15 log units) below what was measured, and the stated range covers the measured number.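

Among the compounds shown here, the exchange of 2-hydroxyphenyl for 4-chlorophenyl on a carbon with a double bond to nitrogen gives the first readable step, with a 2.5-fold higher number from compound 2 to compound 3 (0.40 log units; beyond the scatter) in this assay. This place therefore accepts the change with a modest loss of growth inhibition, and compound 3 still gives a measured number and not a limit. The step carries two changes at once, the hydroxyl leaving and the chlorine entering, and does not separate them.

For the compounds shown here, compound 1 gives a limit and not a number, and no step to it can be read: the limit of > 100000 nM in this assay, at which 1 of the 3 values shown sits. As far as these compounds go, whether plain phenyl or a methoxyphenyl group on that carbon would tell the share of the hydroxyl from that of the chlorine stays open.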